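The compounds below may be only part of what the source reports. "The series", "measured", "known", "first", "only" and "open" are said of these compounds alone.

Measured compounds in a functional assay on MCF7 cells (Homo sapiens) for antiproliferative activity, read by MTT assay, with a stated time of 72 h; a lower number here means a stronger inhibitor, a higher number a weaker inhibitor:
compound 1, `CC/C=C/C(=O)Nc1cccc(Oc2nc(Nc3cccc(OC)c3)nc3c2CSCC3)c1`, compound 1 gives 24200 nM
compound 2, `COc1cccc(Nc2nc3c(c(Oc4cccc(NC(=O)/C=C/C(C)C)c4)n2)CSCC3)c1`, compound 2 gives 21800 nM
compound 3, `CC/C=C/C(=O)Nc1cccc(Oc2nc(Nc3cccc(C#N)c3)nc3c2CSCC3)c1`, compound 3 gives 15900 nM

The three measured values lie close to one another, and none of the steps between them leaves the usual scatter. Compound 1 and compound 2 differ only in the amide side chain: methyl in place of hydrogen on a saturated chain carbon bound to a double-bonded chain carbon and a saturated chain carbon. That change gives a 1.1-fold lower number from compound 1 to compound 2 (0.05 log units; within the scatter).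

Compound 4, `CCC/C=C/C(=O)Nc1cccc(Oc2nc(Nc3cccc(C#N)c3)nc3c2CSCC3)c1`, has not yet been measured in this assay. It stands to compound 3 as compound 2 stands to compound 1, a change of the same kind, though not the same: methyl in place of hydrogen on a saturated chain carbon, two bonds along the chain from a double-bonded chain carbon. The place differs from the earlier case: in compound 2 the methyl enters on a saturated chain carbon bound to a double-bonded chain carbon and a saturated chain carbon, whereas in compound 4 it enters on a saturated chain carbon, two bonds along the chain from a double-bonded chain carbon. Among the compounds considered here this kind of change occurs twice.

The cores of compound 1 and compound 3 differ as follows: cyano in place of methoxy on an aromatic carbon, a change that gives a 1.5-fold lower number from compound 1 to compound 3 (0.18 log units; within the scatter).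

For compound 4 the step from compound 3 is estimated as a 1.1-fold lower number from compound 3 to compound 4 (0.04 log units; within the scatter), resting on the single earlier case, where the added methyl gave a 1.1-fold lower number from compound 1 to compound 2 (0.05 log units; within the scatter) and hence no shift beyond the scatter. Compound 4 is therefore expected to give 14500 nM, with a likely range from 7000 nM to 30000 nM.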

Compound 4, half-maximal inhibitory concentration: 15300 nM
Beside the measured number, compound 4's estimate is 1.1-fold (0.02 log units) below it; low and high end bracket the measured number.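

In this assay, methyl in place of hydrogen on a saturated chain carbon, two bonds along the chain from a double-bonded chain carbon, gives a 1.0-fold lower number from compound 3 to compound 4 (0.02 log units; within the scatter), and the comparison with the earlier methyl step is: the same change on two cores in this assay, a 1.1-fold lower number (0.05 log units; within the scatter) from compound 1 to compound 2 and a 1.0-fold lower number (0.02 log units; within the scatter) from compound 3 to compound 4, 1.1-fold (0.03 log units) apart, within the scatter of two such steps. Within this small set, then, adding a methyl to the amide side chain carries from the methoxy-bearing core of compound 1 to the cyano-bearing core of compound 3 with no shift beyond the scatter on either core. Among the compounds shown here, this does not establish a general rule: there are only two pairs, the methyl enters at a different place in each, and steps this small cannot separate a slight real effect from no effect, nor show that the agreement would hold on any other core.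

Going by these compounds, it remains open whether a longer chain, an amine or a carboxylic acid in the amide side chain would move the number beyond the scatter. Also open, on these data alone, is whether replacing the cyano group with a halogen or a trifluoromethyl group, on either side chain, would do so.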